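The source may hold more compounds than are shown below. What is called first, only, known or untested is meant among the compounds shown, and "the series" means these compounds.

Measured in a functional assay on A2780 ADR cells (Homo sapiens) for cytotoxicity, read by MTT assay, with a stated time of 24 h; on this read-out lower numbers stand for stronger inhibition and higher numbers for weaker inhibition:
Compound 1 `CCCCC[C@@H](C[C@H](O)C[C@@H]1CC=CC(=O)O1)OC`: 26300 nM
Compound 2 `CCCCC[C@@H](C[C@@H](O)C[C@@H]1CC=CC(=O)O1)OC`: 46300 nM
Compound 3 `CCCCC[C@H](C[C@@H](O)C[C@@H]1CC=CC(=O)O1)OC`: 91500 nM

Compound 3 stands clearly apart only from compound 1, with a 3.5-fold higher number from compound 1 to compound 3 (0.54 log units; beyond the scatter), while a 2.0-fold higher number from compound 2 to compound 3 (0.30 log units; within the scatter) keeps it level with compound 2. Compound 4 `CCCCC[C@@H](C[C@H](O)C[C@H]1CC=CC(=O)O1)OC` is still unmeasured. It is the mirror image of compound 3: the two compounds have the same atoms and bonds and differ only in configuration as drawn: 3 of 3 stereo elements differ (all stereocentres are inverted: mirror images); a stereocentre at a saturated chain carbon is drawn R in compound 3 and S in compound 4; a stereocentre at a saturated chain carbon is drawn R in compound 3 and S in compound 4; a stereocentre at a saturated ring carbon is drawn S in compound 3 and R in compound 4. Within the data shown here, the other measured step, a 1.8-fold higher number from compound 1 to compound 2 (0.25 log units; within the scatter), also changed a chain carbon, and no measured step touches the ring carbon, so that part of the change is untested. Among the measured compounds shown here, only the step with two inverted chain carbons exceeded the scatter, and reversing those two carbons points to lower numbers in this assay. The expected change is a 2.3-fold lower number from compound 3 to compound 4 (0.36 log units; beyond the scatter), a modest estimated step. Compound 4 is estimated at 40000 nM, with an expected range from 15000 nM to 100000 nM.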

Compound 4, half-maximal inhibitory concentration: 48000 nM
The estimate for compound 4 lay 1.2-fold (0.08 log units) below the measured number; the range from low to high includes it.
By their numbers in this assay, from the lowest: compounds 1, 2, 4 and 3 (each within the scatter of the next, the first and the last beyond it).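

In this assay, inverting all three stereocentres gives a 1.9-fold lower number from compound 3 to compound 4 (0.28 log units; within the scatter), so this mirror-image pair stays within the scatter. Among these compounds, the ring carbon is tested here for the first time: inverting it alone gives a 1.8-fold higher number from compound 1 to compound 4 (0.26 log units; within the scatter), and inverting it together with one chain carbon gives a 1.0-fold higher number from compound 2 to compound 4 (0.02 log units; within the scatter). Neither change at this saturated ring carbon moves the number beyond the scatter.

All the compounds shown have the same atoms and bonds, so the effect of any change in structure remains open. What a longer chain, or an amine in place of the hydroxyl group, would do cannot be told from them.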